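The source may report more compounds than this note shows. Statements on the series, on what has been measured and on what is new or still open speak of the compounds shown alone.

Among the compounds with values here, in a functional assay, read by spectrophotometry, with a stated time of 3 min (a higher number here means a weaker inhibitor, a lower number a stronger inhibitor), three compounds have numbers so far. Compound 1 `Cc1ccc2[nH]c(=O)c(/C=N/c3ccccc3O)cc2c1` gives 8240 nM, compound 2 `O=c1[nH]c2ccccc2cc1/C=N/Nc1ccc([N+](=O)[O-])cc1` gives 11400 nM, and compound 3 `O=c1[nH]c2ccccc2cc1/C=N/Nc1ccccc1` gives 11800 nM. Compound 2 thus lies within the usual scatter of both other compounds, and these numbers set no clear order among them.

Compound 4 `O=c1[nH]c2ccccc2cc1/C=N/Nc1ccc([N+](=O)[O-])cc1[N+](=O)[O-]` keeps all of compound 2 and carries one more group: nitro in place of hydrogen on an aromatic carbon. This is nitro in place of hydrogen on an aromatic carbon, ortho to a large group and meta to a nitro group.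

Within the data shown here, the one measured step that bears on this change replaces a nitro group with hydrogen, a 1.0-fold higher number from compound 2 to compound 3 (0.01 log units; within the scatter), and on that step alone no change beyond the scatter is expected in this assay. Among the measured compounds shown here, that step concerns the nitro group already present, so no measurement yet covers the new place, and the guide is a loose one. The estimate amounts to an expected 1.1-fold lower number from compound 2 to compound 4 (0.06 log units; within the scatter). For compound 4, the estimated value is 10000 nM, with an expected range from 4000 nM to 22000 nM.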

Compound 4, half-maximal inhibitory concentration: 142000 nM
Compound 4: the middle estimate sits 14-fold (1.15 log units) below what was measured; the measured number lies above the stated range.
By their numbers in this assay, from the lowest: compounds 1, 2 and 3 (each within the scatter of the next); then compound 4.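

In this assay, this aromatic carbon, ortho to a large group and meta to a nitro group, is sensitive to the change: nitro in place of hydrogen here gives a much weaker inhibitor (a 12-fold higher number from compound 2 to compound 4 (1.10 log units; beyond the scatter)). The nitro group already on compound 2 behaves differently, since replacing it with hydrogen changes little (a 1.0-fold higher number from compound 2 to compound 3 (0.01 log units; within the scatter)), so the same group matters in one place on this ring and not in the other. Nothing given here provides a measured reason for this loss of strength.

From the compounds shown here alone, it remains open whether the loss belongs to nitro itself or to any group on this carbon; an amine or a chlorine atom there would help to tell these apart. Going by these compounds, it is also open whether nitro at this place has the same effect without the first nitro group.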